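Methoxy to isopropoxy on the shared core

The source may report more compounds than this note shows. Statements on the series, on what has been measured and on what is new or still open speak of the compounds shown alone.

Compound 1 `O=C(/C=C/c1csc2ccccc12)c1ccccc1O`: 5300 nM
Compound 2 `O=C(/C=C/c1csc2ccccc12)c1cc(Br)ccc1O`: 660 nM
Compound 3 `COc1ccc(O)c(C(=O)/C=C/c2csc3ccccc23)c1`: 580 nM

These values come from a functional assay on A549 cells (Homo sapiens) for antiproliferative activity, read by sulforhodamine B assay, with a stated time of 72 h; a lower number here means a stronger inhibitor, a higher number a weaker inhibitor. Compound 3 is level with compound 2, and both lie under compound 1. Compound 4 `CC(C)Oc1ccc(O)c(C(=O)/C=C/c2csc3ccccc23)c1` alters one group of compound 3: isopropyl in place of methyl on an oxygen on an aromatic ring. Bromo and methoxy gave steps of similar size, an 8.0-fold lower number from compound 1 to compound 2 (0.90 log units; beyond the scatter) and a 9.1-fold lower number from compound 1 to compound 3 (0.96 log units; beyond the scatter), while a 1.1-fold lower number from compound 2 to compound 3 (0.06 log units; within the scatter) stays within the scatter. Within the data shown here, no measured step changes the group on that oxygen, so this guidance is indirect. No step beyond the scatter is therefore expected in this assay. The expected change is a 1.2-fold higher number from compound 3 to compound 4 (0.08 log units; within the scatter). Compound 4 is estimated at 700 nM, with an expected range of 280 nM to 1800 nM.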

Compound 4, half-maximal inhibitory concentration: 6400 nM
The estimate for compound 4 lay 9.1-fold (0.96 log units) below the measured number; measured number outside the range, above it.
By their numbers in this assay, from the lowest: compounds 3 and 2 (each within the scatter of the next); then compounds 1 and 4 (each within the scatter of the next).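

In this assay the group on this oxygen clearly matters: isopropyl in place of methyl gives an 11-fold higher number from compound 3 to compound 4 (1.04 log units; beyond the scatter) and so removes the gain that methoxy brought to the shared core. Isopropoxy also does not match bromo at this place, with a 9.7-fold higher number from compound 2 to compound 4 (0.99 log units; beyond the scatter), and it is level with plain hydrogen, with a 1.2-fold higher number from compound 1 to compound 4 (0.08 log units; within the scatter). Nothing available here explains this loss. Still open, on these data alone, is whether ethoxy on this oxygen would stay with methoxy or fall with isopropoxy, and how a free hydroxyl would compare.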